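Removing the Ring Methyl from Compound 2

The source may hold more compounds than are shown below. What is called first, only, known or untested is meant among the compounds shown, and "the series" means these compounds.

In a functional assay on MCF7 cells (Homo sapiens) for cytotoxicity, read by MTT assay, with a stated time of 72 h, tested at 10 uM (on this read-out higher numbers stand for more inhibition of growth at the one concentration tested and lower numbers for less inhibition of growth), compound 1 `N/C(=N\NC(=S)N1CCCC1)c1ccc(F)cn1` gives 54.5%, while compound 2 `Cc1cccc(/C(N)=N/NC(=S)N2CCCC2)n1` gives 38.2%, the lower of the two numbers shown, a gap beyond the usual scatter. Compound 3 `N/C(=N\NC(=S)N1CCCC1)c1ccccn1` differs from compound 2 in one place: hydrogen in place of methyl on an aromatic carbon, next to the ring nitrogen. Among the compounds with values here, no measured pair shows this exact change, so the size of the step is uncertain; a small rise toward the number of compound 1 seems plausible, though one within the scatter cannot be excluded. The step of a number 6.8 percentage points higher from compound 2 to compound 3 (within the scatter) is therefore expected to be modest. Compound 3 is estimated at 45%, with a range from 25% to 65%.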

Compound 3, percent growth inhibition at one concentration: 51.7%
Compound 3: the middle estimate sits 6.7 percentage points below what was measured; low and high end bracket the measured number.
By their numbers in this assay, from the lowest: compound 2; then compounds 3 and 1 (each within the scatter of the next).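

In this assay the methyl on an aromatic carbon, next to the ring nitrogen, proves to matter: hydrogen in its place gives a number 13.5 percentage points higher from compound 2 to compound 3 (beyond the scatter) for this pair. Hydrogen in place of fluoro on an aromatic carbon gives a number 2.8 percentage points lower from compound 1 to compound 3 (within the scatter) and so separates compound 1 and compound 3 by no more than ordinary scatter. Nothing available explains either step. The compounds shown leave open how an ethyl group, a methoxy group or an amine on the methyl-bearing carbon would read, and whether the lower number of compound 2 extends to any group besides methyl.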